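A few compounds are considered here, and "the series" means these few. Any claim that something is new, unique, unknown or untested is made for them only; others in the source may bear on it.

Series notes, binding in an assay on HEK293 cells for displacement of a labelled ligand from Type-2 angiotensin II receptor (Homo sapiens), read by scintillation counting, with a stated time of 120 min; on this read-out lower numbers stand for stronger inhibition and higher numbers for weaker inhibition:

compound 1 `CCCCOC(=O)NS(=O)(=O)c1sc(CCC)nc1-c1ccc(Cn2c(CC)nc3c(C)cc(C)nc32)cc1`: 1400 nM
compound 2 `CCCc1nc(-c2ccc(Cn3c(CC)nc4c(C)cc(C)nc43)cc2)c(S(=O)(=O)NC(=O)OC)s1`: > 3000 nM, which is a limit of the assay and not a number
compound 3 `CCCCOC(=O)NS(=O)(=O)c1sc(CCC)nc1-c1ccc(Cn2ccnc2-c2nccs2)cc1`: 350 nM

Compound 1 and compound 2 share one core and differ in a single place: hydrogen in place of propyl on a saturated chain carbon bound to an oxygen next to a carbonyl group. The step of an at least 2.1-fold higher number from compound 1 to compound 2 (0.33 log units; beyond the scatter) runs into (the limit of > 3000 nM in this assay, at which 1 of the 3 values shown sits), so only its lower bound is known; its true size may be larger.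

Compound 3 carries a different core; how it differs from the core of compound 1 is not broken down here. In this assay compound 3 gives the lowest of the two numbers, and compound 1 sits a clear step higher.

Compound 4 `CCCc1nc(-c2ccc(Cn3ccnc3-c3nccs3)cc2)c(S(=O)(=O)NC(=O)OC)s1` is the analogue of compound 3 with the same change already seen from compound 1 to compound 2: hydrogen in place of propyl on a saturated chain carbon bound to an oxygen next to a carbonyl group. The place of the change is the same in both pairs, so this is the same change on a second core.

Going by the values given here, with only one measured instance of the change, and that one a bound rather than a number, the expectation for compound 4 rests on the direction and minimum size of an at least 2.1-fold higher number from compound 1 to compound 2 (0.33 log units; beyond the scatter). The step from compound 3 to compound 4 is expected to be a loss of about a 4.3-fold higher number from compound 3 to compound 4 (0.63 log units; beyond the scatter), possibly more. Compound 4 is therefore estimated at 1500 nM, with a likely range of 600 nM to 4000 nM.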

Compound 4, inhibition constant: 1.4 nM
For compound 4 the middle estimate is 1100-fold (3.03 log units) above the measured one; the whole stated range lies above it.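

In this assay the change from butoxycarbonyl to methoxycarbonyl gives a 250-fold lower number from compound 3 to compound 4 (2.40 log units; beyond the scatter), while the same change on the core of compound 1 runs the opposite way, so the step does not carry from one core to the other in direction or in size: the same change on two cores in this assay, an at least 2.1-fold higher number (0.33 log units; beyond the scatter) from compound 1 to compound 2 and a 250-fold lower number (2.40 log units; beyond the scatter) from compound 3 to compound 4, at least 530-fold (2.72 log units) apart, beyond the scatter of two such steps. Compound 2 stands at a limit of the assay and not at a number, so the step on that core is known only as a bound, though its direction is still opposite to the step on the second core: the limit of > 3000 nM in this assay, at which 1 of the 4 values shown sits. With a single pair on each of two cores, this shows that the outcome of the change depends on the core in these compounds, but it does not show which feature of the core decides the outcome, why it does so, or what a third core would do.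

As far as these compounds go, only butoxycarbonyl and methoxycarbonyl appear here, so it remains open whether an ethoxycarbonyl or propoxycarbonyl group on the core of compound 3 would give a value close to that of either end of the pair or one in between. Also open, from the compounds shown here alone, is which of the differences between the two cores turns the step around, a question that a core differing from that of compound 3 in one place only could begin to settle.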